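Halogen swap on a sulfonyl aryl group in a pyrazole series

The source may report more compounds than this note shows. Statements on the series, on what has been measured and on what is new or still open speak of the compounds shown alone.

Three compounds sharing one core were tested in a functional assay on A549 cells (Homo sapiens) for antiproliferative activity, read by MTT assay, with a stated time of 24 h; on this read-out higher numbers stand for weaker inhibition and lower numbers for stronger inhibition. Compound 1 `Cc1ccc(-c2nn(-c3ccccc3)cc2-c2nc3ccccc3n2S(=O)(=O)c2ccc(Cl)cc2)cc1` gives 3550 nM. Compound 2 `Cc1ccc(-c2nn(-c3ccccc3)cc2-c2nc3ccccc3n2S(=O)(=O)c2ccc(Br)cc2)cc1` gives 1860 nM. Compound 3 `O=S(=O)(c1ccc(Cl)cc1)n1c(-c2cn(-c3ccccc3)nc2-c2ccc(C(F)(F)F)cc2)nc2ccccc21` gives 2560 nM. Compound 2 differs from compound 1 by bromo in place of chloro on an aromatic carbon, and this gave a 1.9-fold lower number from compound 1 to compound 2 (0.28 log units; within the scatter). Compound 3 differs from compound 1 by trifluoromethyl in place of methyl on an aromatic carbon, which gave a 1.4-fold lower number from compound 1 to compound 3 (0.14 log units; within the scatter).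

Compound 4 `O=S(=O)(c1ccc(Br)cc1)n1c(-c2cn(-c3ccccc3)nc2-c2ccc(C(F)(F)F)cc2)nc2ccccc21` has not yet been measured. It differs from compound 3 by bromo in place of chloro on an aromatic carbon, the same change as from compound 1 to compound 2, at a place described in the same words. Because the earlier step was a 1.9-fold lower number from compound 1 to compound 2 (0.28 log units; within the scatter), compound 4 is expected to show a 1.6-fold lower number from compound 3 to compound 4 (0.20 log units; within the scatter) in this assay, a step of the same kind, though the earlier one lay within scatter and so the expectation is loose. Compound 4 is estimated at 1600 nM, most likely between 800 nM and 3200 nM.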

Compound 4, half-maximal inhibitory concentration: 1690 nM
The estimate for compound 4 lay 1.1-fold (0.02 log units) below the measured number; low and high end bracket the measured number.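

In this assay, bromo in place of chloro on the trifluoromethyl core gave a 1.5-fold lower number from compound 3 to compound 4 (0.18 log units; within the scatter), and trifluoromethyl in place of methyl on the bromo core gave a 1.1-fold lower number from compound 2 to compound 4 (0.04 log units; within the scatter). Each change therefore reads alike on both cores, but with so few pairs this is agreement only among these four compounds, and the bromo comparison stands thus: the same change on two cores in this assay, a 1.9-fold lower number (0.28 log units; within the scatter) from compound 1 to compound 2 and a 1.5-fold lower number (0.18 log units; within the scatter) from compound 3 to compound 4, 1.3-fold (0.10 log units) apart, within the scatter of two such steps Every step lies within the scatter, so neither change is shown to alter the read-out on either core, and the trifluoromethyl comparison stands thus: the same change on two cores in this assay, a 1.4-fold lower number (0.14 log units; within the scatter) from compound 1 to compound 3 and a 1.1-fold lower number (0.04 log units; within the scatter) from compound 2 to compound 4, 1.3-fold (0.10 log units) apart, within the scatter of two such steps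

Going by these compounds, how an iodo or a fluoro group in place of the chloro would read remains open. So does the effect of an amine or a carboxylic acid in place of the methyl.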